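The compounds below may be only part of what the source reports. "The series", "measured", "known", "first", "only" and "open" are said of these compounds alone.

The measured compounds are compound 1 `Cc1cc(C)c2c(O)cc(-c3ccc(Cl)cc3)nc2n1` with 19500 nM in a functional assay on cells (Tumor Cell line, Homo sapiens) for cytotoxicity (on this read-out lower numbers stand for stronger inhibition of growth and higher numbers for weaker inhibition of growth), compound 2 `Cc1ccnc2nc(-c3ccc(Cl)cc3)cc(O)c12` with 5130 nM, and compound 3 `COc1ccccc1-c1cc(O)c2cccnc2n1` with 40700 nM.

Compound 1 and compound 2 share a core and differ by one change, (methyl in place of hydrogen on an aromatic carbon). This change brought a 3.8-fold higher number from compound 2 to compound 1 (0.58 log units; beyond the scatter). Among the measured compounds shown here, compound 3 carries a different core; how its core differs from that of compound 2 is not broken down here, and the two values show only that compound 3 gives the higher number of the two.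

Compound 4 `COc1ccccc1-c1cc(O)c2cc(C)cnc2n1` is yet to be measured. It differs from compound 3 by methyl in place of hydrogen on an aromatic carbon. For the measured compounds named here, this is the same kind of change as the one from compound 2 to compound 1, but not the same: there the methyl enters next to the ring nitrogen and meta to a methyl group, here it enters two atoms from the ring nitrogen. For compound 4 the step from compound 3 is expected to be a 2.0-fold higher number from compound 3 to compound 4 (0.29 log units; within the scatter) in this assay, weaker than the earlier one because a 3.8-fold higher number from compound 2 to compound 1 (0.58 log units; beyond the scatter) came on a core with another methyl present. Compound 4 is therefore estimated at 80000 nM, between 30000 nM and 220000 nM.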

Compound 4, concentration for 50% growth inhibition: 31600 nM
Beside the measured number, compound 4's estimate is 2.5-fold (0.40 log units) above it; the measured number falls inside the stated range.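

In this assay, methyl in place of hydrogen on an aromatic carbon gave a 1.3-fold lower number from compound 3 to compound 4 (0.11 log units; within the scatter), so on the core of compound 3 the change left the number within the scatter. The size of the step did not carry over between the two cores: the same change on two cores in this assay, a 3.8-fold higher number (0.58 log units; beyond the scatter) from compound 2 to compound 1 and a 1.3-fold lower number (0.11 log units; within the scatter) from compound 3 to compound 4, 4.9-fold (0.69 log units) apart, beyond the scatter of two such steps. This shows that the step seen on one core cannot simply be transferred to the other in this series, but two pairs do not show whether the gap follows from the place of the new methyl, from the methyl already present on compound 2, or from the other differences between the cores.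

From the compounds shown here alone, it remains open whether a different group at the place taken by the methyl in compound 4, such as an amine, a carboxylic acid or a longer chain, would shift the number in this assay. Going by these compounds, it also remains open whether either core would respond to such a group as it did to methyl.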